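Dropping the methylsulfonyl group: compound 3 to compound 4

The source may report more compounds than this note shows. Statements on the series, on what has been measured and on what is new or still open speak of the compounds shown alone.

Series notes. In a functional assay on CHO-K1 cells for antagonist activity at C-X-C chemokine receptor type 3 (Homo sapiens), read by FLIPR, with a stated time of 10 min, in the presence of a further agent that is not named here (a higher number here means a weaker inhibitor, a lower number a stronger inhibitor), compound 1 `Cc1nn(CC(=O)N2CCN(c3sc(C(F)(F)F)nc3-c3nc4ccccc4[nH]3)C[C@H]2C)cc1CN(C)C` gives 2.7 nM, compound 2 `C[C@@H]1CN(c2sc(C(F)(F)F)nc2-c2nc3ccccc3[nH]2)CCN1C(=O)Cn1cc(C2CCN(C)CC2)cn1` gives 15 nM and compound 3 `Cc1nc(C)n(CC(=O)N2CCN(c3sc(C(F)(F)F)nc3-c3nc4ccc(S(C)(=O)=O)cc4[nH]3)C[C@H]2C)n1` gives 10 nM. Compound 3 thus holds the second highest of the three numbers; its value and that of compound 2 lie within the scatter of each other, while compound 1 shows a lower number. Going by the values given here, the only single-place step measured, a 5.6-fold higher number from compound 1 to compound 2 (0.74 log units; beyond the scatter), alters the group on the saturated chain carbon bound to the carbonyl carbon and does not touch the site changed here. Compound 4 `Cc1nc(C)n(CC(=O)N2CCN(c3sc(C(F)(F)F)nc3-c3nc4ccccc4[nH]3)C[C@H]2C)n1` differs from compound 3 by hydrogen in place of methylsulfonyl on an aromatic carbon. Among the compounds with values here, no measured step informs this site, so no change beyond the scatter is expected in this assay. The expected step is a 1.3-fold lower number from compound 3 to compound 4 (0.10 log units; within the scatter). Compound 4 is estimated at 8 nM, within 3 nM to 25 nM.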

Compound 4, half-maximal inhibitory concentration: 3.2 nM
Compound 4: the middle estimate sits 2.5-fold (0.40 log units) above what was measured; measured number inside the range.
By their numbers in this assay, from the lowest: compounds 1 and 4 (each within the scatter of the next); then compounds 3 and 2 (each within the scatter of the next).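

In this assay, going by these compounds alone, hydrogen in place of methylsulfonyl on the aromatic carbon gives a 3.1-fold lower number from compound 3 to compound 4 (0.49 log units; beyond the scatter) and is the first measured step at this position, with the lower number on the side without the sulfone. On the saturated chain carbon, 3,5-dimethyl-1H-1,2,4-triazol-1-yl gives a 4.7-fold lower number from compound 2 to compound 4 (0.67 log units; beyond the scatter) against the 4-(1-methylpiperidin-4-yl)-1H-pyrazol-1-yl group, yet a 1.2-fold higher number from compound 1 to compound 4 (0.07 log units; within the scatter) against the 4-((dimethylamino)methyl)-3-methyl-1H-pyrazol-1-yl group, so no amine in this side group is needed to reach the lowest numbers of the series. Nothing available explains these steps.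

Going by these compounds, only methylsulfonyl and hydrogen are compared on this aromatic carbon, so a fluorine, a nitrile or an amine there remains open. On these data alone, whether the methylsulfonyl step carries over to compounds with the amine-bearing pyrazole groups also remains open.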